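The source may report more compounds than this note shows. Statements on the series, on what has been measured and on what is new or still open speak of the compounds shown alone.

Among the compounds with values here, in a functional assay with Oryctolagus cuniculus as the target (a lower number here means a stronger inhibitor, a higher number a weaker inhibitor), compound 3 `COc1ccc(-c2nc(CN(C)C)sc2-c2ccc(OC)cc2)cc1` gives 96 nM, the only value that is not a limit. Compound 1 `COc1ccc(-c2nc(/N=C(\N)NC3CCCCC3)sc2-c2ccc(OC)cc2)cc1` reads > 1000 nM, which is a limit. Compound 2 `COc1ccc(-c2nc(/N=C(\N)n3ccnc3)sc2-c2ccc(OC)cc2)cc1` reads > 100 nM, also a limit.

Compound 4 `COc1ccc(-c2nc(CNC(=O)CSc3ccccc3)sc2-c2ccc(OC)cc2)cc1` carries (((phenylsulfanyl)methyl)carbonyl)amino in place of dimethylamino on a saturated chain carbon bound to an aromatic carbon. Within the data shown here, two measured steps bear on this, though both act on an aromatic carbon. The step of an at least 10-fold lower number from compound 1 to compound 3 (1.01 log units; beyond the scatter) is large, while the floor of an at least 1.0-fold lower number from compound 2 to compound 3 (0.01 log units; that floor lies within the scatter) lies within the scatter. Compound 4 regains a larger group, so the expected step is a 4.2-fold higher number from compound 3 to compound 4 (0.62 log units; beyond the scatter), toward a higher number in this assay. The estimate for compound 4 is 400 nM, with an expected range of 80 nM to 3000 nM.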

Compound 4, half-maximal inhibitory concentration: < 100 nM
Compound 4: only a limit was reported (the forecaster's own chance of this, stated with the estimate: 40%); middle value at least 4.0-fold (0.60 log units) away from the limit.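

Within the data shown here, compound 4 reads < 100 nM, which is a limit, so no step from compound 3 to compound 4 can be read. The compounds shown leave open whether (((phenylsulfanyl)methyl)carbonyl)amino in place of dimethylamino changes the number at all, and in which direction.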